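One Substituent Swap and a Hemolysis Read-out

The source may report more compounds than this note shows. Statements on the series, on what has been measured and on what is new or still open speak of the compounds shown alone.

For the measured compounds named here, compound 3 `N=C(N)c1ccc(-c2ccc(-c3ccc(F)cc3)s2)s1` carries the top number among the three measured so far in an ADME assay on cells (Erythrocyte, Homo sapiens) for activation, read by hemolysis, with a stated time of 30 min, tested at 10 mM (on this read-out higher numbers stand for a stronger effect at the one concentration tested and lower numbers for a weaker effect), where compound 3 gives 93.3%. The other two are compound 2 `N=C(N)c1ccc(-c2ccc(-c3ccccc3)s2)s1`, which in this assay gives 85.1%, and compound 1 `N=C(N)c1ccc(-c2ccc(-c3ccc(Cl)cc3)s2)s1`, which in this assay gives 81.7%. Going by the values given here, the step of a number 8.2 percentage points higher from compound 2 to compound 3 (within the scatter) leaves those two compounds sitting together within the usual scatter, and only the step of a number 11.6 percentage points higher from compound 1 to compound 3 (beyond the scatter) lies beyond it, and that one is modest.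

Compound 4 `COc1ccc(-c2ccc(-c3ccc(C(=N)N)s3)s2)cc1` differs from compound 3 in a single place: methoxy in place of fluoro on an aromatic carbon. The measured steps that bear on this change are those that alter the same aromatic carbon. Both a number 3.4 percentage points higher from compound 1 to compound 2 (within the scatter) and a number 8.2 percentage points higher from compound 2 to compound 3 (within the scatter) fall within the scatter, and a number 11.6 percentage points higher from compound 1 to compound 3 (beyond the scatter) is only modest. Across the three compounds, changing what sits on this carbon has moved the read-out little, although none of them carries a methoxy group there, so this group itself is untested in the series. The expectation for compound 4 in this assay is therefore a step of a number 7.3 percentage points lower from compound 3 to compound 4 (within the scatter) with no size beyond the scatter. Compound 4 is thus estimated at 86%, with a range from 70% to 98%.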

Compound 4, a percentage reported as activity, at one concentration (the size of the read-out at that concentration, not a potency): 92.7%
The estimate for compound 4 lay 6.7 percentage points below the measured number; the measured number falls inside the stated range.
By their numbers in this assay, from the lowest: compounds 1, 2, 4 and 3 (each within the scatter of the next, the first and the last beyond it).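

Methoxy brings 2 heavy atoms and 1 hydrogen-bond acceptor to the aromatic carbon where fluoro had 1 heavy atom and no acceptor, yet in this assay the change gives only a step of a number 0.6 percentage points lower from compound 3 to compound 4 (within the scatter), so compound 3 and compound 4 cannot be told apart. Set against hydrogen, the same group gives a step of a number 7.6 percentage points higher from compound 2 to compound 4 (within the scatter), while set against chloro it gives a step of a number 11 percentage points higher from compound 1 to compound 4 (beyond the scatter), so among these four compounds only the chloro compound, compound 1, stands apart from compound 3 and compound 4, and then only modestly, with compound 2 separated from none of the others. Nothing at hand explains why these different groups give such closely matched read-outs.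

The compounds shown leave open whether an amine, a carboxylic acid or a longer chain such as ethoxy on this carbon would also stay close to compound 3 and compound 4. They also leave open whether these small differences would hold at other concentrations or alongside changes elsewhere on the shared core.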